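This account rests on a few compounds, and the source may have more. Where it says the series, first, only, none or still open, it means among the compounds named here.

Three compounds share one core and differ only in the ring attached to the carbonyl carbon. Compound 1 `COc1ccc(/C=C/c2cc(OC)cc(OC)c2/C=C/C(=O)c2ccccc2)cc1` carries a plain phenyl there, and in a functional assay on A549 cells (Homo sapiens) for antiproliferative activity, read by MTT assay, with a stated time of 48 h (a higher number here means a weaker inhibitor, a lower number a stronger inhibitor), compound 1 gives 3.9 ug/mL. Compound 2 `COc1ccc(/C=C/c2cc(OC)cc(OC)c2/C=C/C(=O)c2ccc(C(F)(F)F)cc2)cc1` has a trifluoromethyl on that phenyl; in this assay compound 2 gives 7.8 ug/mL. Compound 3 `COc1ccc(/C=C/c2cc(OC)cc(OC)c2/C=C/C(=O)c2ccccc2C)cc1` bears a methyl instead, and in this assay compound 3 gives 5.9 ug/mL. Compound 2 stands within the scatter of both of the others: a 2.0-fold higher number from compound 1 to compound 2 (0.30 log units; within the scatter) and a 1.3-fold lower number from compound 2 to compound 3 (0.12 log units; within the scatter), so the three numbers cannot be told apart.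

Compound 4 `CCN(CC)c1ccc(C(=O)/C=C/c2c(/C=C/c3ccc(OC)cc3)cc(OC)cc2OC)cc1` has not yet been measured. It differs from compound 2 in one place: diethylamino in place of trifluoromethyl on an aromatic carbon. The measured steps that bear on this position are a 2.0-fold higher number from compound 1 to compound 2 (0.30 log units; within the scatter), which left the trifluoromethyl within the scatter of hydrogen, and a 1.5-fold higher number from compound 1 to compound 3 (0.18 log units; within the scatter), which did the same for methyl. Going by the values given here, no measured compound shows what a diethylamino group does here, so there is no ground to expect a step beyond the scatter in this assay, in either direction. Compound 4 is therefore expected to give about 5.5 ug/mL, with a range from 2.5 ug/mL to 12 ug/mL, which amounts to an estimated 1.4-fold lower number from compound 2 to compound 4 (0.15 log units; within the scatter).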

Compound 4, half-maximal inhibitory concentration: 5.4 ug/mL
For compound 4 the middle estimate is 1.0-fold (0.01 log units) above the measured one; low and high end bracket the measured number.
By their numbers in this assay, from the lowest: compounds 1, 4, 3 and 2 (each within the scatter of the next).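

In this assay a much different group on the same aromatic carbon still does not move the number beyond the scatter: diethylamino, which brings nitrogen and a hydrogen-bond acceptor that trifluoromethyl lacks, gives a 1.4-fold lower number from compound 2 to compound 4 (0.16 log units; within the scatter) and, in place of hydrogen, a 1.4-fold higher number from compound 1 to compound 4 (0.14 log units; within the scatter). The 4-(diethylamino)phenyl ring also cannot be told apart from the 2-methylphenyl ring on the carbonyl carbon, with a 1.1-fold lower number from compound 3 to compound 4 (0.04 log units; within the scatter), so all the changes of this ring shown so far stay within the scatter in this assay and none can be ranked against another. No measurement is available that would explain why these compounds cannot be told apart.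

The compounds shown leave open whether any group on this ring can move the number beyond the scatter, for instance a carboxylic acid, a primary amine or a longer chain in place of the ethyl groups on the nitrogen. They also leave open what a change elsewhere on the shared core would do, such as replacing a methoxy group with a hydroxyl.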